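Swapping Ethyl for Tert-Butyl on the Amide Nitrogen

This account rests on a few compounds, and the source may have more. Where it says the series, first, only, none or still open, it means among the compounds named here.

Measured compounds:
compound 1, `COc1cc2c(cc1OC)C(CC(=O)N(C)C)CC2`; in a functional assay on the whole organism (strain Wistar) for inhibition, with Rattus norvegicus as the target, read by paw edema, with stated times of 60 min and 2 h, at a dose of 100 mg/kg by the oral route (on this read-out higher numbers stand for more inhibition at the one dose given (going by the name of the read-out) and lower numbers for less inhibition), compound 1 gives 36%.
compound 2, `CCNC(=O)CC1CCc2cc(OC)c(OC)cc21`; in this assay compound 2 gives 26%.
compound 3, `CCCCNC(=O)CC1CCc2cc(OC)c(OC)cc21`; in this assay compound 3 gives 24%.

The three compounds share one core and differ only in the group carried by the amide. Compound 2 holds the second highest of the three numbers, but its position is loose: the step of a number 2 percentage points lower from compound 2 to compound 3 (within the scatter) and the step of a number 10 percentage points lower from compound 1 to compound 2 (within the scatter) both fall within the scatter, so compound 2 cannot be ordered against either neighbour. Only the longer step of a number 12 percentage points lower from compound 1 to compound 3 (beyond the scatter) is beyond the scatter, and modestly so.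

Compound 4, `COc1cc2c(cc1OC)C(CC(=O)NC(C)(C)C)CC2`, differs from compound 2 in one place: tert-butyl in place of ethyl on an amide-type nitrogen. Within the data shown here, the steps that bear on this are the changes of the alkyl on the amide nitrogen already measured. Growing the chain gave a number 2 percentage points lower from compound 2 to compound 3 (within the scatter), and replacing dimethylamino gave a number 10 percentage points lower from compound 1 to compound 2 (within the scatter) and a number 12 percentage points lower from compound 1 to compound 3 (beyond the scatter), so enlarging this group has at most shifted the read-out modestly downward. A step of no more than the scatter is therefore expected, a number 3 percentage points lower from compound 2 to compound 4 (within the scatter), with a slight lean downward. Compound 4 is estimated to give 23% in this assay, within a range from 10% to 38%.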

Compound 4, a percentage reported as inhibition, in the whole organism at one dose (the size of the read-out at that dose, not a potency): 32%
Compound 4: the middle estimate sits 9 percentage points below what was measured, within the range that was stated.
By their numbers in this assay, from the lowest: compounds 3, 2, 4 and 1 (each within the scatter of the next, the first and the last beyond it).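

Tert-butyl is the first branched group on this amide nitrogen, and in this assay the change from ethyl reads as a number 6 percentage points higher from compound 2 to compound 4 (within the scatter) and the change from butyl as a number 8 percentage points higher from compound 3 to compound 4 (within the scatter), so neither step can be read as a real shift. Among these compounds, it also goes against the slight downward drift hinted at by the earlier compounds as the group on the nitrogen grew: the comparison with the dimethylamino compound gives a number 4 percentage points lower from compound 1 to compound 4 (within the scatter), and compound 4 therefore cannot be ordered against any of the other three, even though compound 1 and compound 3 stand beyond the scatter of each other. Nothing measured here explains why the numbers fall as they do.

Going by these compounds, whether a cyclohexyl ring, or a chain ending in a hydroxyl group, on this nitrogen would move the read-out beyond the scatter stays open. On these data alone, every number here also comes from a single dose, so how the four compounds would compare in potency remains unknown.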